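Cytotoxicity notes: ring-nitrogen substituent change in the series

This account rests on a few compounds, and the source may have more. Where it says the series, first, only, none or still open, it means among the compounds named here.

Measured so far in an ADME assay on Huh-7 cells (Homo sapiens) for cytotoxicity, with a stated time of 72 h; on this read-out lower numbers stand for higher toxicity in this test and higher numbers for lower toxicity in this test:
compound 1, `CS(=O)(=O)Nc1ccc2c(c1)S(=O)(=O)N=C(C1=C(O)C3CCCC3N(CCC3CC3)C1=O)N2`: > 33000 nM, a limit of the test.
compound 2, `CC(C)CCN1C(=O)C(C2=NS(=O)(=O)c3cc(NS(C)(=O)=O)ccc3N2)=C(O)C2CCCC21`: > 1000 nM, likewise only a limit.

Compound 2 stands at the limit of > 1000 nM in this assay, at which 1 of the 2 values shown sits. Going by the values given here, the one other value, that of compound 1, stands at the limit of > 33000 nM in this assay, at which 1 of the 2 values shown sits. Among the compounds with values here, the single measured step, a step that the two limits leave unreadable from compound 1 to compound 2, is therefore unreadable in size and direction.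

Compound 3, `CS(=O)(=O)Nc1ccc2c(c1)S(=O)(=O)N=C(C1=C(O)C3CCCC3N(C3CCCCC3)C1=O)N2`, differs from compound 2 by cyclohexyl in place of isopentyl on an amide-type nitrogen in a ring. Within the data shown here, no measured step touches this substituent change, so the expectation rests only on the two limits, which together point to low toxicity across the series so far. In this assay compound 3 is expected to sit again at or beyond a limit, with no step beyond the scatter. Compound 3 is estimated at 30000 nM, range 5000 nM to 100000 nM. The step this estimate implies, a step that the limit leaves unreadable from compound 2 to compound 3, is expected to be nominal only.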

Compound 3, half-maximal cytotoxic concentration: > 10000 nM
Compound 3 was reported as a limit; the forecaster's own chance of this, stated with the estimate: 80%; the middle value does not contradict the limit.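

Compound 3, like compound 1 and compound 2, is reported only as a limit in this assay, so the steps from compound 1 and from compound 2 to compound 3 cannot be read. The compounds shown leave open whether the substituent on the amide-type nitrogen in a ring changes cytotoxicity at all.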